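Trifluoromethoxy in place of fluoro on compound 3

A few compounds are considered here, and "the series" means these few. Any claim that something is new, unique, unknown or untested is made for them only; others in the source may bear on it.

In a functional assay on Gurav cells (Homo sapiens) for inhibition, read by sulforhodamine B assay (on this read-out lower numbers stand for stronger inhibition of growth and higher numbers for weaker inhibition of growth), compound 3 `Oc1cccc2[nH]c(-c3ccc(-c4ccc(-c5ccc(F)cc5)cc4)cc3)nc12` has the lowest of the three measured numbers at 2860 nM and so shows the strongest growth inhibition so far. Compound 1 `Cc1ccc2[nH]c(-c3ccc(-c4ccc(-c5ccc(N(C)C)cc5)cc4)cc3)nc2c1` follows at 6240 nM and compound 2 `Fc1ccc(-c2ccc(-c3ccc(-c4nc5ccccc5[nH]4)cc3)cc2)cc1` gives 100000 nM on the same read-out.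

The next molecule is compound 4 `Oc1cccc2[nH]c(-c3ccc(-c4ccc(-c5ccc(OC(F)(F)F)cc5)cc4)cc3)nc12` and the change that leads to it is trifluoromethoxy in place of fluoro on an aromatic carbon with trifluoromethoxy in place of fluoro on an aromatic carbon, para to a large group. The hydroxy group of compound 3 stays in place.

Among the compounds with values here, only one measured step links two compounds that differ in a single place. That step is a 35-fold lower number from compound 2 to compound 3 (1.54 log units; beyond the scatter) and it is large, but it comes from hydroxy in place of hydrogen on an aromatic carbon, which is a different change. Compound 1 differs from compound 3 in more than one place, so its higher number isolates no single change.

No measurement tests the new swap, and the data give no direction for it, so the best guess stays with compound 3. An estimated 1.0-fold higher number from compound 3 to compound 4 (0.02 log units; within the scatter) is what this reasoning expects in this assay with no step beyond the scatter foreseen. The expected value for compound 4 is 3000 nM with an estimated range of 1000 nM to 10000 nM around it.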

Compound 4, concentration for 50% growth inhibition: 3600 nM
Estimate against measurement, compound 4: 1.2-fold (0.08 log units) below; the range from low to high includes it.
By their numbers in this assay, from the lowest: compounds 3, 4 and 1 (each within the scatter of the next, the first and the last beyond it); then compound 2.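

In this assay, going from 4-fluorophenyl to 4-(trifluoromethoxy)phenyl gives a 1.3-fold higher number from compound 3 to compound 4 (0.10 log units; within the scatter), so on this aromatic carbon, para to a large group, fluoro and trifluoromethoxy cannot be told apart, even though the entering group has 5 heavy atoms where the leaving one has 1. Within the data shown here, this is the first measured change at this position, and it stands in contrast to the change at the hydroxy position, where a 35-fold lower number from compound 2 to compound 3 (1.54 log units; beyond the scatter) shows that a single replacement can move the number far beyond the scatter. The data offer no measurement that would explain why these two groups read alike here.

From the compounds shown here alone, this is one pair, and both of its compounds carry the hydroxy group, so it remains open whether the swap would read the same in a compound without the hydroxy group, such as compound 2. Going by these compounds, it also remains open whether this position would tolerate a group of a different kind, such as a carboxylic acid or a longer alkyl chain, as well as it tolerates these two.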